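This account rests on a few compounds, and the source may have more. Where it says the series, first, only, none or still open, it means among the compounds named here.

Compound 1 `Cn1c(Cc2ccccc2C(F)(F)F)nc(C(=O)NCC2CCCCC2)c(O)c1=O`: > 100000 nM
Compound 2 `CCn1c(Cc2ccccc2C(F)(F)F)nc(C(=O)NCc2ccccc2)c(O)c1=O`: > 100000 nM
Compound 3 `CC(c1ccccc1C(F)(F)F)c1nc(C(=O)NCc2ccccc2)c(O)c(=O)n1C`: > 100000 nM

The measurement here is an ADME assay on HepG2 cells (Homo sapiens) for cytotoxicity, in the presence of a further agent that is not named here; a higher number here means a weaker inhibitor, a lower number a stronger inhibitor. Compound 1 reads > 100000 nM, which is a limit of the assay and not a number. Compound 2 reads > 100000 nM, again a limit. Compound 3 reads > 100000 nM, also a limit. All three share one position, (the limit of > 100000 nM in this assay, at which 3 of the 3 values shown sit), so no order among them can be read.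

Compound 4 `Cn1c(Cc2ccccc2C(F)(F)F)nc(C(=O)NCc2ccc(F)cc2)c(O)c1=O` has not yet been measured. It keeps the core of compound 1 and changes only the group on the amide: 4-fluorophenyl in place of cyclohexyl on a saturated chain carbon bound to an amide-type nitrogen. In words, 4-fluorophenyl stands in place of cyclohexyl on a saturated chain carbon bound to an amide-type nitrogen, so cyclohexylmethyl gives way to 4-fluorobenzyl.

For the measured compounds named here, no two measured compounds differ in just one place, so the data offer no step to compare this one with. The expectation rests on compound 1, whose limit is > 100000 nM. The expected a number no higher from compound 1 to compound 4 (the limit leaves the size open) is no change beyond the usual scatter, in neither direction, and another limit reading is likely. For compound 4 the estimated value is 100000 nM, with an expected range from 50000 nM to 100000 nM.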

Compound 4, half-maximal inhibitory concentration: > 100000 nM
Compound 4: a limit, no number; the forecaster's own chance of this, stated with the estimate: 85%; the middle value lies on the limit itself.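

Compound 1 and compound 4 both sit at a limit of the assay and not at a number, so no step between them can be read: the limit of > 100000 nM in this assay, at which 4 of the 4 values shown sit.

What the compounds shown leave open is whether any change to the shared core or its groups would give a reading inside the range of this assay and how far apart these four compounds truly lie.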